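Replacing furan-2-yl with naphthalen-2-yl on a carbonyl carbon

The source may hold more compounds than are shown below. What is called first, only, known or untested is meant among the compounds shown, and "the series" means these compounds.

- Compound 1 `COc1ccc([C@H]2[C@H](NC(=O)c3ccc(Cl)cc3)C(=O)N2c2cc(OC)c(OC)c(OC)c2)cc1O`: 271 nM
- Compound 2 `COc1ccc([C@H]2[C@H](NC(=O)c3ccco3)C(=O)N2c2cc(OC)c(OC)c(OC)c2)cc1O`: 18.6 nM

Within the data shown here, in a functional assay on SW48 cells (Homo sapiens) for antiproliferative activity, read by MTT assay, with a stated time of 72 h (a higher number here means a weaker inhibitor, a lower number a stronger inhibitor), compound 2 gives 18.6 nM, the lower of the two numbers so far. Compound 3 `COc1ccc([C@H]2[C@H](NC(=O)c3ccc4ccccc4c3)C(=O)N2c2cc(OC)c(OC)c(OC)c2)cc1O` keeps the shared core and changes one group: naphthalen-2-yl in place of furan-2-yl on a carbonyl carbon. Put simply, naphthalen-2-yl stands in place of furan-2-yl on a carbonyl carbon.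

Among the measured compounds shown here, only one measured step bears on this change. Going from 4-chlorophenyl to furan-2-yl at that carbonyl carbon gave a 15-fold lower number from compound 1 to compound 2 (1.16 log units; beyond the scatter), a large change beyond the scatter. Going by these compounds, compound 3 also loses furan-2-yl, so that step is reversed in spirit, though naphthalen-2-yl itself is untested and one step is thin evidence. A step of similar size towards a higher number, meaning a weaker inhibitor, is therefore expected in this assay. The expected move is a 12-fold higher number from compound 2 to compound 3 (1.07 log units; beyond the scatter). For compound 3 the estimated value is 220 nM, with an expected range of 45 nM to 1000 nM.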

Compound 3, half-maximal inhibitory concentration: 220 nM
Beside the measured number, compound 3's estimate shows no gap at the digits printed; the measured number falls inside the stated range.
By their numbers in this assay, from the lowest: compound 2; then compounds 3 and 1 (each within the scatter of the next).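

In this assay, the step of a 12-fold higher number from compound 2 to compound 3 (1.07 log units; beyond the scatter) shows that furan-2-yl stands apart from a second group on this carbonyl carbon, not only from 4-chlorophenyl. The step of a 1.2-fold lower number from compound 1 to compound 3 (0.09 log units; within the scatter) lies within the scatter, so this assay does not separate naphthalen-2-yl, with its two six-membered aromatic rings, from 4-chlorophenyl, with one such ring. Nothing available explains why the furan-2-yl compound gives the lowest number of the three.

The compounds shown leave open whether the low number depends on the oxygen of the furan ring or on the five-membered ring itself. A thiophen-2-yl group, with sulfur in place of that oxygen, or a small open chain such as an ethyl group on the same carbonyl carbon, would help to separate these possibilities.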